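Pentan-3-yl to cyclopentyl on the ether oxygen

The source may hold more compounds than are shown below. What is called first, only, known or untested is meant among the compounds shown, and "the series" means these compounds.

Values in a physicochemical assay for lipophilicity, using the shake flask method; on this read-out higher numbers stand for higher lipophilicity and lower numbers for lower lipophilicity:
compound 1 `CC(C)Oc1cc(Oc2cnc(C(=O)N(C)C)nc2)cc(-c2nccc(=O)[nH]2)c1`: 0.97
compound 2 `CCC(CC)Oc1cc(Oc2cnc(C(=O)N(C)C)nc2)cc(-c2nccc(=O)[nH]2)c1`: 1.91

Compound 2, at 1.91, holds the higher of the two numbers. The step under review leads to compound 3 `CN(C)C(=O)c1ncc(Oc2cc(OC3CCCC3)cc(-c3nccc(=O)[nH]3)c2)cn1`: cyclopentyl in place of pentan-3-yl on an oxygen on an aromatic ring, with cyclopentyl in place of pentan-3-yl on an oxygen on an aromatic ring. Going by the values given here, the only measured step that bears on it is a number 0.94 log units higher from compound 1 to compound 2 (beyond the scatter), a modest change with pentan-3-yl in place of isopropyl on the same oxygen. Among the compounds with values here, no measured compound carries a ring at this place, so that step is only a rough guide. Working from compound 2 and that step, a smaller move downward in this assay is expected, leaving compound 3 within the span set by compound 1 and compound 2. The expected change is a number 0.36 log units lower from compound 2 to compound 3 (beyond the scatter). For compound 3 the estimate is 1.55, with an expected range of 1.2 to 1.9.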

Compound 3, distribution coefficient: 1.74
The estimate for compound 3 lay 0.19 log units below the measured number, within the range that was stated.
By their numbers in this assay, from the lowest: compound 1; then compounds 3 and 2 (each within the scatter of the next).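

In this assay, closing the pentan-3-yl chain into cyclopentyl on this oxygen gives a number 0.17 log units lower from compound 2 to compound 3 (within the scatter), so the open chain and the ring, each with the same heavy atom count, cannot be told apart here on this read-out. Cyclopentyl in place of isopropyl gives a number 0.77 log units higher from compound 1 to compound 3 (beyond the scatter), and with a number 0.94 log units higher from compound 1 to compound 2 (beyond the scatter) alongside it, both groups of five carbons stand clear of isopropyl in the same direction. The data offer no explanation for either result.

Open, from the compounds shown here alone, is how this assay responds on this oxygen to a ring carrying an oxygen atom, such as tetrahydropyranyl, or to a chain ending in an amine. Also open, going by these compounds, is whether cyclohexyl and a longer chain would likewise fall within the scatter of each other.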